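The source may report more compounds than this note shows. Statements on the series, on what has been measured and on what is new or still open speak of the compounds shown alone.

Measured compounds:
- compound 1 `CCOC(=O)c1cccc(-c2ccc(N(C)C)cc2)c1`, in an assay on COS-7 cells for inhibition of patatin-like phospholipase domain-containing protein 2 (Mus musculus), tested at 200 uM (on this read-out higher numbers stand for more inhibition at the one concentration tested (going by the name of the read-out) and lower numbers for less inhibition), compound 1 gives 87%
- compound 2 `CN(C)c1ccc(-c2cccc([N+](=O)[O-])c2)cc1`, compound 2 gives 21%
- compound 3 `CCOC(=O)Nc1cccc(-c2ccc(N(C)C)cc2)c1`, compound 3 gives 93%

Compound 3 carries the highest number of the three. Compound 1 sits close by, the step from the ester being a number 6 percentage points higher from compound 1 to compound 3 (within the scatter), so the two cannot be ordered. For the measured compounds named here, compound 2 lies far below, with a number 72 percentage points higher from compound 2 to compound 3 (beyond the scatter) and a number 66 percentage points lower from compound 1 to compound 2 (beyond the scatter), the only changes that go beyond the scatter; both concern swapping the whole group on the aromatic carbon.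

Compound 4 `CC(C)OC(=O)Nc1cccc(-c2ccc(N(C)C)cc2)c1` keeps the carbamate and differs from compound 3 only by methyl in place of hydrogen on a saturated chain carbon bound to an oxygen next to a carbonyl group and a saturated chain carbon. Going by the values given here, none of the measured steps touches the ethyl of the ester or the carbamate, so no step bears directly on this change. The closest guide is that ester and carbamate give numbers within the scatter of each other, so the numbers in this assay stay level across that part of the molecule. The expected outcome is therefore no step beyond the scatter, a number 3 percentage points lower from compound 3 to compound 4 (within the scatter).

Compound 4 is estimated at 90%, within 75% to 99%.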

Compound 4, a percentage reported as inhibition, at one concentration (the size of the read-out at that concentration, not a potency): 69%
Compound 4: the middle estimate sits 21 percentage points above what was measured; measured number below the stated range.
By their numbers in this assay, from the lowest: compound 2; then compound 4; then compounds 1 and 3 (each within the scatter of the next).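

In this assay the alkyl end of the carbamate proves not to be a silent position: ethyl to isopropyl alone gives a number 24 percentage points lower from compound 3 to compound 4 (beyond the scatter), whereas the swap between ester and carbamate stayed within the scatter. The isopropyl carbamate also separates from the ethyl ester (a number 18 percentage points lower from compound 1 to compound 4 (beyond the scatter)), yet it remains far above the nitro compound (a number 48 percentage points higher from compound 2 to compound 4 (beyond the scatter)), so this methyl on the saturated chain carbon lowers the number without removing the inhibition seen for the carbamate. Nothing at hand explains the drop at this position.

On these data alone, whether the fall follows branching or simply the added carbon stays open, and a straight propyl chain or a tert-butyl on the carbamate oxygen would help separate the two. As far as these compounds go, it is also open whether an isopropyl ester would follow the carbamate.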